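The source may report more compounds than this note shows. Statements on the series, on what has been measured and on what is new or still open speak of the compounds shown alone.

Of the compounds shown here, two have been measured in an assay on isolated protein for agonist activity at prostaglandin E2 receptor EP4 subtype (Homo sapiens); a higher number here means that more compound is needed for the effect, a lower number that less compound is needed. Compound 1, `CC(C)(CCCCF)[C@H](O)/C=C/[C@H]1COC(=O)N1CCSc1nc(C(=O)O)cs1`, gives 1220 nM in that assay. Compound 2, `O=C(O)c1csc(SCCN2C(=O)OC[C@@H]2/C=C/[C@@H](O)C2(CCc3ccccc3)CCC2)n1`, gives 465 nM in this assay, the lower of the two numbers; the number for compound 1 is higher by a gap that lies beyond the usual scatter of repeated measurements.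

The step now under consideration leads from compound 2 to compound 3, `CC#CCC1([C@H](O)/C=C/[C@H]2COC(=O)N2CCSc2nc(C(=O)O)cs2)CCC1`. The change is prop-1-yn-1-yl in place of benzyl on a saturated chain carbon bound to a saturated ring carbon: a benzyl group gives way to prop-1-yn-1-yl, so the group on the saturated chain carbon bound to the saturated ring carbon becomes shorter and loses its aromatic ring. Among the measured compounds shown here, no measured pair shows this particular exchange, so the expectation rests on compound 2 alone. The number for compound 3 is expected to come out somewhat higher, by a step of about a 1.4-fold higher number from compound 2 to compound 3 (0.15 log units; within the scatter), though a result within the scatter of compound 2 would not surprise. The estimate for compound 3 in this assay is 650 nM, with a range from 220 nM to 1900 nM.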

Compound 3, half-maximal effective concentration: 240 nM
The estimate for compound 3 lay 2.7-fold (0.43 log units) above the measured number; the range from low to high includes it.
By their numbers in this assay, from the lowest: compounds 3 and 2 (each within the scatter of the next); then compound 1.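

With prop-1-yn-1-yl in place of benzyl, this assay gives a 1.9-fold lower number from compound 2 to compound 3 (0.29 log units; within the scatter), so at this position a shorter group without an aromatic ring still gives a number within the scatter of compound 2. The aromatic ring of compound 2 is therefore not required for a number of this size. Setting 1-(but-2-yn-1-yl)cyclobutyl in place of 5-fluoro-1,1-dimethylpentyl gives a 5.1-fold lower number from compound 1 to compound 3 (0.71 log units; beyond the scatter), which shows that the choice of whole group at this place can matter beyond the scatter, although no measurement here explains either step.

Whether the triple bond itself matters stays open, as no compound shown has a saturated butyl chain in place of but-2-yn-1-yl. How a longer alkyne chain or an amine at the end of this group would read is also unknown.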